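From chloro to trifluoromethyl at the stability limit

A few compounds are considered here, and "the series" means these few. Any claim that something is new, unique, unknown or untested is made for them only; others in the source may bear on it.

Values in an ADME assay on microsomes from liver (Homo sapiens) for metabolic stability, read by LC-MS, with NADPH named in the record, with a stated time of 60 min, tested at 1 uM, in the absence of a further agent; a higher number here means that more of the compound is left, a lower number that less of the compound is left:
Compound 1 `COc1ccc(-c2c(C)nc3c(N4CC[C@@H](NS(C)(=O)=O)C4)cc(C)nn23)cc1OC`: > 95%
Compound 2 `COc1ccc(-c2c(C)nc3c(N4CC[C@@H](NS(=O)(=O)C5CC5)C4)cc(C)nn23)cc1OC`: > 95%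
Compound 3 `COc1ccc(-c2c(C)nc3c(N4CC[C@@H](NS(=O)(=O)c5ccc(Cl)cc5)C4)cc(C)nn23)cc1OC`: > 95%

Compound 3 gives > 95%, which is a limit of the assay and not a number. The whole set stands at the limit of > 95% in this assay, at which 3 of the 3 values shown sit. Compound 4 `COc1ccc(-c2c(C)nc3c(N4CC[C@@H](NS(=O)(=O)c5ccc(C(F)(F)F)cc5)C4)cc(C)nn23)cc1OC` has trifluoromethyl in place of chloro on an aromatic carbon.

The measured changes on the sulfonyl sulfur are a step that the two limits leave unreadable from compound 1 to compound 2, a step that the two limits leave unreadable from compound 1 to compound 3 and a step that the two limits leave unreadable from compound 2 to compound 3. None of them has a readable size, so they show no shift in this assay, and no step beyond the scatter is expected. The estimate is a step that the limit leaves unreadable from compound 3 to compound 4, an expected step within the scatter. Compound 4 is expected at 96%, with an estimated range of 85% to 100%.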

Compound 4, percent of the compound remaining: > 95%
Compound 4: only a limit was reported; the forecaster's own chance of this, stated with the estimate: 70%; the middle value does not contradict the limit.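

Compound 4 also sits at a limit of the assay, so the steps to it from compound 1, compound 2 and compound 3 cannot be read: the limit of > 95% in this assay, at which 4 of the 4 values shown sit. The compounds shown leave open whether any of these groups on the sulfonyl sulfur changes the percent of compound remaining in this assay at all.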